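The compounds below may be only part of what the source reports. "The series", "measured", "known", "first", "only" and "open" are said of these compounds alone.

Measured compounds in the series so far:

- compound 1, `Cc1ccc2oc(-c3cc4ccccc4s3)cc(=O)c2c1` — 15.6 ug/mL
- compound 2, `Cc1ccc(O)c(C(=O)CC(=O)c2cc3ccccc3s2)c1` — 7.12 ug/mL

Both numbers come from an ADME assay on HeLa cells (Homo sapiens) for inhibition, read by MTT assay, with a stated time of 72 h; on this read-out lower numbers stand for stronger inhibition of growth and higher numbers for weaker inhibition of growth. On this read-out compound 2 carries the lower of the two values; compound 1 stands above it by a gap that falls beyond the usual scatter, so compound 2 is the stronger of the pair on these two points alone. Going by the values given here, no step between measured compounds differing in one place is available, so the series gives no direct calibration for the change that leads to the next compound.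

Compound 3 is `O=C(CC(=O)c1cc(Br)ccc1O)c1cc2ccccc2s1` and has not yet been run in this assay. It differs from compound 2 in one place: bromo in place of methyl on an aromatic carbon. Nothing measured here bears on what bromo in place of methyl on an aromatic carbon does to growth inhibition, so the expectation rests on the general observation that single-atom swaps of this kind tend to move this read-out modestly. The expected step in this assay is a 1.1-fold lower number from compound 2 to compound 3 (0.04 log units; within the scatter), that is, little change or none beyond the scatter. For compound 3 the estimate is 6.5 ug/mL, with a range from 2.5 ug/mL to 16 ug/mL, to be checked once the measurement is in.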

Compound 3, concentration for 50% growth inhibition: 6.75 ug/mL
For compound 3 the middle estimate is 1.0-fold (0.02 log units) below the measured one, and the stated range covers the measured number.
By their numbers in this assay, from the lowest: compounds 3 and 2 (each within the scatter of the next); then compound 1.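

Bromo in place of methyl, on the aromatic carbon para to a hydroxy group and meta to a large group, gives the series its only one-place step so far, and in this assay that step reads a 1.1-fold lower number from compound 2 to compound 3 (0.02 log units; within the scatter) and leaves the two compounds indistinguishable. Going by these compounds alone, this position therefore accepts either of these two single-heavy-atom groups with no change in growth inhibition beyond the scatter, which the earlier pair of values could not show, as no one-place step was then available. Nothing measured alongside these values speaks to why methyl and bromo read alike at this carbon.

Methyl and bromo are the only groups shown at this position, so it remains open whether an amine, a carboxylic acid, a methoxy group or a longer chain on the same carbon would also leave growth inhibition unchanged or would shift it beyond the scatter. On these data alone, it also remains open whether bromo in place of methyl would read the same way on the core of compound 1, or whether the flat result holds only for the open-chain core shared by compound 2 and compound 3.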